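The compounds below may be only part of what the source reports. "The series", "measured", "known", "first", "only" and "open" are said of these compounds alone.

Measured in a functional assay on HepG2 cells (Homo sapiens) for cytotoxicity, read by WST assay, with a stated time of 24 h; on this read-out higher numbers stand for lower toxicity in this test and lower numbers for higher toxicity in this test:
- compound 1 `CCCCCCCc1cc(-c2ccc3cc(C(=O)O)ccc3c2)ccc1O`: 1.89 ug/mL
- compound 2 `CCCCCc1cc(-c2ccc3cc(CO)ccc3c2)ccc1O`: 3.27 ug/mL
- compound 3 `CCCCCCCc1cc(-c2ccc3cc(CO)ccc3c2)ccc1O`: 3.61 ug/mL

Compound 1 stands within the scatter of both compound 2 and compound 3, so the three form a single group with no readable order.

Compound 4 `O=C(O)c1ccc2cc(-c3ccc(O)cc3)ccc2c1` is not yet measured. Its difference from compound 1 is hydrogen in place of heptyl on an aromatic carbon, ortho to a hydroxy group.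

Among the measured compounds shown here, two measured steps bear on this only partly. The chain step, a 1.1-fold higher number from compound 2 to compound 3 (0.04 log units; within the scatter), is small and adds only ethyl. The step at the other end of the core, a 1.9-fold higher number from compound 1 to compound 3 (0.28 log units; within the scatter), is also small. For the measured compounds named here, no measured compound lacks the chain, so removing all of it goes beyond the data, and any forecast is uncertain. A step beyond the scatter in this assay is tentatively expected, toward a higher number. The estimated change is a 7.9-fold higher number from compound 1 to compound 4 (0.90 log units; beyond the scatter). For compound 4 the expected value is 15 ug/mL, with an estimated range of 4 ug/mL to 60 ug/mL.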

Compound 4, concentration lethal to 50% of the cells: > 32 ug/mL
Compound 4: a limit, no number; the forecaster's own chance of this, stated with the estimate: 25%; middle value at least 2.1-fold (0.32 log units) from the limit.
By their numbers in this assay, from the lowest: compounds 1, 2 and 3 (each within the scatter of the next). At a limit, above all of these: compound 4.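

In this assay compound 4 gives > 32 ug/mL, which is a limit of the assay and not a number. With hydrogen in place of heptyl, ortho to a hydroxy group, the series shows its first step beyond the scatter: an at least 16-fold higher number from compound 1 to compound 4 (1.22 log units; beyond the scatter). Lengthening the chain in the hydroxymethyl compounds gave only a 1.1-fold higher number from compound 2 to compound 3 (0.04 log units; within the scatter), so at this position the read-out responds strongly to the complete loss of the chain, whereas that ethyl extension stays within the scatter.

Still open, going by these compounds, is whether a short chain such as methyl or propyl at this position would give a number closer to compound 1 or compound 4, and how a longer chain or an amine would behave there. On these data alone, it is also open whether hydrogen in place of the chain gives a similar step in the hydroxymethyl compounds.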